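Ortho-Methyl on the Biaryl Amide of Compound 1

The compounds below may be only part of what the source reports. "The series", "measured", "known", "first", "only" and "open" are said of these compounds alone.

Measured compounds:
compound 1, `COc1cc2c(Oc3ccc(NC(=O)c4cc(-c5ccccc5)ccn4)cc3F)ccnc2cc1OCCCN1CCN(C)CC1`, 82 nM
compound 2, `COc1cc2c(Oc3ccc(NC(=O)c4cc(-c5ccc(C(F)(F)F)cc5)ccn4)cc3F)ccnc2cc1OCCCN1CCCCC1`, 230 nM

In a functional assay on HT-29 cells (Homo sapiens) for cytotoxicity, read by MTT assay, with a stated time of 72 h (a lower number here means a stronger inhibitor, a higher number a weaker inhibitor), compound 1 gives 82 nM, the lowest of the two numbers recorded. Compound 2 gives a higher number, 230 nM, and the gap between these two values lies beyond the scatter; compound 2 differs from compound 1 in more than one place, so no single structural step accounts for it.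

Compound 3, `COc1cc2c(Oc3ccc(NC(=O)c4cc(-c5ccccc5C)ccn4)cc3F)ccnc2cc1OCCCN1CCN(C)CC1`, is not yet measured. It differs from compound 1 in one place: methyl in place of hydrogen on an aromatic carbon.

For the measured compounds named here, no measured pair isolates this change, so the expectation rests on compound 1 alone. The step from compound 1 to compound 3 in this assay is expected to be small, of the order of the scatter, with a slight lean toward a higher number: a 1.5-fold higher number from compound 1 to compound 3 (0.17 log units; within the scatter). Compound 3 is therefore estimated at 120 nM, within a range of 40 nM to 400 nM.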

Compound 3, half-maximal inhibitory concentration: 180 nM
Beside the measured number, compound 3's estimate is 1.5-fold (0.18 log units) below it, and the stated range covers the measured number.
By their numbers in this assay, from the lowest: compound 1; then compounds 3 and 2 (each within the scatter of the next).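

For the compounds shown here, this is the first step that changes one place only. In this assay, going from phenyl to 2-methylphenyl gives a 2.2-fold higher number from compound 1 to compound 3 (0.34 log units; beyond the scatter), so a single methyl ortho to a large group is enough to carry the number past the scatter, although the step is modest. Compound 1 still holds the lowest number of those shown, so this methyl brings no gain here, and no supporting measurement is available to explain the shift.

The compounds shown leave open whether the same step would follow with a fluorine, a chlorine or a methoxy group in place of the methyl. They also leave open whether a methyl on another carbon of this phenyl ring would give a step of similar size.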